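The source may report more compounds than this note shows. Statements on the series, on what has been measured and on what is new or still open speak of the compounds shown alone.

Measured compounds: compound 1 `CCCc1cc(C(C)=O)c(O)cc1OCCCCC#N`, compound 2 `CCCCc1cc(C(C)=O)c(O)cc1OCCCCC#N`, compound 3 `C=CCc1cc(C(C)=O)c(O)cc1OCCCC`.

In an assay on isolated protein for binding affinity to leukotriene B4 receptor 1 (Homo sapiens), tested at 1 uM (on this read-out higher numbers stand for more inhibition at the one concentration tested (going by the name of the read-out) and lower numbers for less inhibition), compound 1 gives 37%. Compound 2 differs from compound 1 by methyl in place of hydrogen on a saturated chain carbon, three bonds along the chain from an aromatic carbon, and in this assay compound 2 gives 13%; the step is a number 24 percentage points lower from compound 1 to compound 2 (beyond the scatter). Compound 3 gives 8% in this assay, and its values sit within the scatter of those of compound 2. The difference between the cores of compound 1 and compound 3 is not broken down here.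

Compound 4 `C=CCc1cc(C(C)=O)c(O)cc1OCCCCC` differs from compound 3 by methyl in place of hydrogen on a saturated chain carbon, four bonds along the chain from an oxygen on an aromatic ring. This is the same kind of change as that from compound 1 to compound 2, though the place differs: three bonds along the chain from an aromatic carbon there, four bonds along the chain from an oxygen on an aromatic ring here. Because compound 3 already gives 8%, the room for a fall of the size seen from compound 1 to compound 2 is small; compound 4 is expected to move by a number 3 percentage points lower from compound 3 to compound 4 (within the scatter). For compound 4 the estimate in this assay is 5%, between 0% and 18%.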

Compound 4, a percentage reported as inhibition, at one concentration (the size of the read-out at that concentration, not a potency): 23%
The estimate for compound 4 lay 18 percentage points below the measured number; the whole stated range lies below it.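

In this assay the methyl-for-hydrogen change gives a step of a number 15 percentage points higher from compound 3 to compound 4 (beyond the scatter). Set beside the earlier step, the same kind of change moves the read-out in opposite directions on the two cores: the same change on two cores in this assay, a number 24 percentage points lower (beyond the scatter) from compound 1 to compound 2 and a number 15 percentage points higher (beyond the scatter) from compound 3 to compound 4, 39 percentage points apart, beyond the scatter of two such steps This shows that the result of the change cannot simply be carried from one core to the other in this series, but it does not show why, as the methyl enters three bonds along the chain from an aromatic carbon in one case and four bonds along the chain from an oxygen on an aromatic ring in the other.

The compounds shown leave open whether a longer chain at that second place would go on raising the number. From the compounds shown here alone, how a carboxylic acid or an amine at the end of that chain would read also remains open.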